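Swapping the piperidine substituent at the aminopyridine position

The compounds below may be only part of what the source reports. "The series", "measured", "known", "first", "only" and "open" are said of these compounds alone.

Measured compounds:
compound 1, `Cc1ccc(Nc2nc(C(F)(F)F)ccc2CNC(=O)C(C)c2ccc(NS(C)(=O)=O)c(F)c2)cc1C`, 39.3 nM
compound 2, `CC(C(=O)NCc1ccc(C(F)(F)F)nc1N(C)C)c1ccc(NS(C)(=O)=O)c(F)c1`, 19.1 nM
compound 3, `CC(C(=O)NCc1ccc(C(F)(F)F)nc1N1CCC(c2ccccc2)CC1)c1ccc(NS(C)(=O)=O)c(F)c1`, 0.6 nM

In a functional assay on CHO-K1 cells for antagonist activity at transient receptor potential cation channel subfamily V member 1 (Homo sapiens), read by FLIPR (a lower number here means a stronger inhibitor, a higher number a weaker inhibitor), compound 3 stands lowest of the three numbers, with compound 2 nearest and compound 1 furthest. The step of a 32-fold lower number from compound 2 to compound 3 (1.50 log units; beyond the scatter) and the step of a 66-fold lower number from compound 1 to compound 3 (1.82 log units; beyond the scatter) both show that placing a 4-phenylpiperidin-1-yl group on this aromatic carbon brings a large gain, while a 2.1-fold lower number from compound 1 to compound 2 (0.31 log units; beyond the scatter) is only modest.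

Compound 4, `CC(C(=O)NCc1ccc(C(F)(F)F)nc1N1CCC(=O)CC1)c1ccc(NS(C)(=O)=O)c(F)c1`, differs from compound 3 by 4-oxopiperidin-1-yl in place of 4-phenylpiperidin-1-yl on an aromatic carbon. Among the compounds with values here, no measured step replaces the phenyl group on the piperidine with an oxo group, so the bearing steps are only indirect: the large step from compound 2 to compound 3 suggests that the 4-phenylpiperidin-1-yl group carries much of the difference between compound 2 and compound 3. Removing its phenyl ring and leaving a 4-oxopiperidin-1-yl group is therefore expected to move this assay in the direction of a higher number, by a step estimated at a 25-fold higher number from compound 3 to compound 4 (1.40 log units; beyond the scatter). Compound 4 is estimated to give 15 nM, with a range from 3 nM to 80 nM.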

Compound 4, inhibition constant: 91 nM
Compound 4: the middle estimate sits 6.1-fold (0.78 log units) below what was measured; the whole stated range lies below it.
By their numbers in this assay, from the lowest: compound 3; then compound 2; then compound 1; then compound 4.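

In this assay, the step (a 150-fold higher number from compound 3 to compound 4 (2.18 log units; beyond the scatter)) shows that the piperidine ring alone does not carry the gain seen with the 4-phenylpiperidin-1-yl group, since the 4-oxopiperidin-1-yl group keeps that ring and loses the large gain. The 4-oxopiperidin-1-yl group also reads weaker than the open-chain dimethylamino group (a 4.8-fold higher number from compound 2 to compound 4 (0.68 log units; beyond the scatter)) and the (3,4-dimethylphenyl)amino group (a 2.3-fold higher number from compound 1 to compound 4 (0.36 log units; beyond the scatter)), so a piperidine at this position brings no advantage by itself. Nothing available explains why these steps take this size.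

This change removes the phenyl ring and adds a carbonyl in one step, so the compounds shown leave open how much of the loss belongs to each. From the compounds shown here alone, how a plain piperidin-1-yl group or a 4-hydroxypiperidin-1-yl group would read at this position also remains open.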